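This account rests on a few compounds, and the source may have more. Where it says the series, first, only, none or still open, it means among the compounds named here.

Measured so far in a functional assay on MCF7 cells (Homo sapiens) for inhibition, read by MTT assay, with a stated time of 3 days; on this read-out lower numbers stand for stronger inhibition and higher numbers for weaker inhibition

Compound 1 `COc1cc(-c2nc3ccccc3s2)ccc1OCC(=O)NNC(O)CN(C)CC(=O)O` gives 1960 nM
Compound 2 `CC[C@H](C)[C@H](NCC(=O)NNC(=O)COc1ccc(-c2nc3ccccc3s2)cc1OC)C(=O)O` gives 1710 nM
Compound 3 `COc1cc(-c2nc3ccccc3s2)ccc1OCC(=O)NNC(=O)CN[C@@H](CS(=O)(=O)O)C(=O)O` gives 1870 nM

These three numbers all lie within the scatter of one another, so compound 3 (1870 nM) cannot be separated from compound 1 or compound 2. Compound 4 `CCOC(=O)[C@H](CS(=O)(=O)O)NCC(=O)NNC(=O)COc1ccc(-c2nc3ccccc3s2)cc1OC` differs from compound 3 in one place (ethyl in place of hydrogen on an oxygen next to a carbonyl group), which turns carboxy into ethoxycarbonyl. Among the compounds with values here, only one measured step offers any guide, and it is an indirect one. That step (a 1.1-fold higher number from compound 2 to compound 3 (0.04 log units; within the scatter)) puts sulfomethyl in place of sec-butyl, a different change elsewhere in the molecule, and it stays within the scatter. Within the data shown here, all three measured compounds carry the carboxy, so no measured pair tests its replacement. With so little evidence, no step beyond the scatter is expected in this assay and no firm direction can be given. The expected step (a 1.2-fold lower number from compound 3 to compound 4 (0.07 log units; within the scatter)) is therefore small, with wide uncertainty. For compound 4 the estimated value is 1600 nM with an expected range from 700 nM to 3500 nM on the same read-out.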

Compound 4, half-maximal inhibitory concentration: 1990 nM
Compound 4: middle estimate off by 1.2-fold (0.09 log units), on the low side; low and high end bracket the measured number.
By their numbers in this assay, from the lowest: compounds 2, 3, 1 and 4 (each within the scatter of the next).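

In this assay, ethyl in place of hydrogen on an oxygen next to a carbonyl group gives the first direct test of the carboxy group, and the step (a 1.1-fold higher number from compound 3 to compound 4 (0.03 log units; within the scatter)) stays within the scatter. The carboxy on this side chain can therefore become ethoxycarbonyl, at least with the sulfo group present, without a readable change in this assay. The larger exchange of 1-carboxy-2-methylbutyl for 1-(ethoxycarbonyl)-2-sulfoethyl on an amine nitrogen also stays within the scatter (a 1.2-fold higher number from compound 2 to compound 4 (0.07 log units; within the scatter)), and no measurement offered here accounts for this flat result.

The compounds shown leave open whether a longer chain on this oxygen, such as butyl or benzyl, would move the number beyond the scatter. They also leave open whether a primary amide in place of the ester would do so.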